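A few compounds are considered here, and "the series" means these few. Any claim that something is new, unique, unknown or untested is made for them only; others in the source may bear on it.

Working notes on the series. In a functional assay on CCRF-CEM cells (Homo sapiens) for inhibition, read by sulforhodamine B assay, with a stated time of 48 h (a lower number here means a stronger inhibitor of growth, a higher number a weaker inhibitor of growth), compound 1 `N#C/C(=C\N1CCN(C(=O)c2ccco2)C1=S)C(=O)c1ccccc1` gives 41900 nM, while compound 2 `O=CN1CCN(c2ccc(Cl)cc2)C1=S` gives 12800 nM. Of the two numbers, compound 2 stands lowest, and the gap to compound 1 is wider than the ordinary scatter of repeated runs, so compound 2 is the stronger growth inhibitor of the pair on what has been measured. The next member, compound 3 `O=CN1CCN(c2ccc(Cl)c(Cl)c2)C1=S`, differs from compound 2 in one place: chloro in place of hydrogen on an aromatic carbon. Among the compounds with values here, no step between two measured compounds shows how a second chloro group on the aryl ring shifts the read-out here, so the expectation leans only on the value of compound 2 and on the small size of the change. A small move toward a lower number is expected, a 1.6-fold lower number from compound 2 to compound 3 (0.20 log units; within the scatter), well within or just at the edge of scatter. Compound 3 is therefore estimated at 8000 nM, in a range from 2500 nM to 30000 nM.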

Compound 3, concentration for 50% growth inhibition: 7100 nM
Beside the measured number, compound 3's estimate is 1.1-fold (0.05 log units) above it; low and high end bracket the measured number.
By their numbers in this assay, from the lowest: compounds 3 and 2 (each within the scatter of the next); then compound 1.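

Within the data shown here, this is the first step that isolates a single change. In this assay the swap of hydrogen for chloro, on an aromatic carbon ortho to a chloro group and meta to a group of 8 heavy atoms, gives a 1.8-fold lower number from compound 2 to compound 3 (0.26 log units; within the scatter). This second chloro group therefore leaves the read-out within the usual scatter, and the position accepts it without a change that can be told from repeat variation. No measurement on hand offers an explanation for this result.

Going by these compounds, it remains open whether a methoxy group, an amine or a carboxylic acid on this same aromatic carbon would read differently from chloro. Also open, on these data alone, is how compound 1 relates to this pair, as it differs from both in more than one place.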